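Trimming the ketone side chain of an mGlu2 modulator

The source may report more compounds than this note shows. Statements on the series, on what has been measured and on what is new or still open speak of the compounds shown alone.

Measured so far:
compound 1, `COc1cc(C(=O)O)ccc1OCCCCOc1ccc(C(=O)CC(C)(C)C)c(O)c1C`, 47 nM
compound 2, `Cc1c(OCCCCOc2cccc(C(=O)O)c2)ccc(C(=O)CC(C)C)c1O`, 222 nM
compound 3, `CCC(=O)c1ccc(OCCCCOc2cc(C(=O)O)ccc2OC)c(C)c1O`, 162 nM

Of the compounds shown here, three have been tested in an assay on HEK293 cells for positive allosteric modulation of metabotropic glutamate receptor 2 (Rattus norvegicus), read by thallium flux, with a stated time of 2.5 min; on this read-out lower numbers stand for an effect already at smaller amounts and higher numbers for an effect only at larger amounts of compound. Compound 1 gives 47 nM, the lowest number of the three, and both other values lie beyond the usual scatter from it: compound 3 gives 162 nM and compound 2 gives 222 nM. Compound 1 is therefore the most potent of the measured set.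

The next compound, compound 4, `CCC(=O)c1ccc(OCCCCOc2ccc(C(=O)O)cc2OC)c(C)c1O`, keeps the whole of compound 1 except for one change: methyl in place of tert-butyl on a saturated chain carbon bound to a carbonyl carbon. Put another way, the neopentylcarbonyl group of compound 1 becomes a propanoyl group in compound 4. For the measured compounds named here, no measured pair shows this exact change on its own, so its effect is not known. Compound 3 also carries a propanoyl group but differs elsewhere from compound 4, so the value that compound 3 gives, 162 nM, only hints that a shorter chain may go with a higher number.

On that basis, compound 4 is expected to show a moderate rise in this assay, a step of a 2.6-fold higher number from compound 1 to compound 4 (0.41 log units; beyond the scatter), with real uncertainty about its size. The estimated value for compound 4 is 120 nM, expected to fall between 45 nM and 320 nM.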

Compound 4, half-maximal effective concentration: 114 nM
For compound 4 the middle estimate is 1.1-fold (0.02 log units) above the measured one, within the range that was stated.
By their numbers in this assay, from the lowest: compound 1; then compounds 4, 3 and 2 (each within the scatter of the next).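

For the compounds shown here, replacing tert-butyl with methyl on a saturated chain carbon bound to a carbonyl carbon is seen here on its own for the first time, and in this assay this change gives a 2.4-fold higher number from compound 1 to compound 4 (0.38 log units; beyond the scatter). The position therefore responds to the change, although the step is modest: a group of 4 heavy atoms gives way to one of 1, and compound 4 still gives 114 nM. No measurement at hand explains why the smaller group goes with the higher number.

On these data alone, a single pair gives only the two end points of this change, so it remains open whether the number climbs steadily through groups such as ethyl, isopropyl or cyclopropyl, or whether a longer chain or an amine at the same place would bring it back down. As far as these compounds go, it is also open whether swapping tert-butyl for methyl would give a step of similar size on a compound whose carboxylic acid and methoxy groups are arranged differently on the benzoic acid part, as they are in compound 3.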